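A few compounds are considered here, and "the series" means these few. Any claim that something is new, unique, unknown or untested is made for them only; others in the source may bear on it.

Within the data shown here, compound 3 `CN1[C@@H]2c3[nH]c4ccccc4c3C[C@H]1[C@H](C#N)N1[C@@H](CNC(=O)c3ccc4ccccc4n3)c3[nH]c4ccccc4c3C[C@@H]21` is, among the three compounds measured so far, the one with the lowest number: in a functional assay on BGC-823 cells (Homo sapiens) for cytotoxicity, read by MTT assay, with a stated time of 72 h (on this read-out higher numbers stand for weaker inhibition and lower numbers for stronger inhibition), compound 3 gives 80 nM. The nearest of the others is compound 1 `CN1[C@@H]2c3[nH]c4ccccc4c3C[C@H]1[C@H](C#N)N1[C@@H](CN3C(=O)c4ccccc4C3=O)c3[nH]c4ccccc4c3C[C@@H]21`, which in this assay gives 410 nM, and the furthest is compound 2 `CN1[C@@H]2c3[nH]c4ccccc4c3C[C@H]1[C@H](C#N)N1[C@@H](CNC(=O)c3cccc(C(F)(F)F)c3)c3[nH]c4ccccc4c3C[C@@H]21`, which gives 870 nM. Among the measured compounds shown here, only one step bears on the change that follows: an 11-fold lower number from compound 2 to compound 3 (1.04 log units; beyond the scatter), which shows that exchanging the group on the carbonyl carbon for a fused two-ring heteroaromatic group moved the number a great deal.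

Compound 4 `CN1[C@@H]2c3[nH]c4ccccc4c3C[C@H]1[C@H](C#N)N1[C@@H](CNC(=O)c3cc4ccccc4o3)c3[nH]c4ccccc4c3C[C@@H]21` is reached from compound 3 by a single change: 1-benzofuran-2-yl in place of quinolin-2-yl on a carbonyl carbon. The new group is again a fused two-ring aromatic system carrying one hydrogen-bond acceptor, so the exchange is closer in kind to keeping the feature that separated compound 3 from compound 2 than to giving it up. For the measured compounds named here, no measured pair shows this exact swap, so the expectation rests on compound 3 alone and on the size of an 11-fold lower number from compound 2 to compound 3 (1.04 log units; beyond the scatter). Compound 4 is expected to give about 150 nM in this assay, within a range of 50 nM to 500 nM. That estimate means a step of a 1.9-fold higher number from compound 3 to compound 4 (0.27 log units; within the scatter), a modest weakening that may well fall within the scatter.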

Compound 4, half-maximal inhibitory concentration: 210 nM
The estimate for compound 4 lay 1.4-fold (0.15 log units) below the measured number; measured number inside the range.
By their numbers in this assay, from the lowest: compound 3; then compounds 4 and 1 (each within the scatter of the next); then compound 2.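

In this assay, the choice of fused two-ring group on the carbonyl carbon matters, and 1-benzofuran-2-yl does not simply stand in for quinolin-2-yl (the change gives a 2.6-fold higher number from compound 3 to compound 4 (0.42 log units; beyond the scatter)). Set against 3-(trifluoromethyl)phenyl, 1-benzofuran-2-yl still gives a clear gain (a 4.1-fold lower number from compound 2 to compound 4 (0.62 log units; beyond the scatter)), though a smaller one than quinolin-2-yl gives (an 11-fold lower number from compound 2 to compound 3 (1.04 log units; beyond the scatter)), so both fused groups lower the number, by different amounts. The comparison with the different group on the saturated chain carbon separates nothing (a 2.0-fold lower number from compound 1 to compound 4 (0.29 log units; within the scatter)), so those two compounds cannot be ranked.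

Nothing available here explains why quinolin-2-yl and 1-benzofuran-2-yl differ. On these data alone, it also remains open whether the second ring is needed at all, which a single-ring pyridin-2-yl on the same carbonyl carbon would test, and how quinolin-2-yl would respond to an added methoxy group or amine.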